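Tert-butyl ester of an inactive bicyclic lactone acid

The compounds below may be only part of what the source reports. "The series", "measured", "known", "first", "only" and "open" are said of these compounds alone.

Compound 1 `CC1(C)[C@@H]2CC3=N[C@@H](CCC(=O)O)C(=O)O[C@@]3(C)[C@H]1C2` carries a 2-carboxyethyl chain on a bicyclic lactone core. In an ADME assay on McCoy cells (Mus musculus) for antiproliferative activity, read by sulforhodamine B assay, with a stated time of 48 h (a higher number here means a weaker inhibitor, a lower number a stronger inhibitor), compound 1 gives only a limit, > 1200000 nM. Its mirror image, compound 2 `CC1(C)[C@H]2CC3=N[C@H](CCC(=O)O)C(=O)O[C@]3(C)[C@@H]1C2`, in this assay likewise gives only a limit, > 1200000 nM. Compound 3 `CC1(C)[C@@H]2CC3=NCC(=O)O[C@@]3(C)[C@H]1C2`, in which hydrogen stands in place of the 2-carboxyethyl, in this assay also gives only a limit, > 900000 nM. The step that the two limits leave unreadable from compound 1 to compound 2 and the step that the two limits leave unreadable from compound 1 to compound 3 thus run between limits and cannot be read for size or direction; what is known of them rests on (the limit of > 1200000 nM in this assay, at which 2 of the 3 values shown sit), the limit of > 900000 nM in this assay, at which 1 of the 3 values shown sits, and (the fact that compounds 1 and 2 differ only in the configuration as drawn).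

Compound 4 `CC(C)(C)OC(=O)CC[C@@H]1N=C2C[C@@H]3C[C@@H](C3(C)C)[C@]2(C)OC1=O` differs from compound 1 by tert-butyl in place of hydrogen on an oxygen next to a carbonyl group. Among the compounds with values here, no measured step touches this oxygen, and the two steps that exist, from the inverted configuration and from the removed chain, both left the compound at a limit and offer no direction for the new change. Compound 4 is therefore expected to give 1200000 nM, within 300000 nM to 5000000 nM, and most probably to be reported only as a limit again. The expected step of a number no higher from compound 1 to compound 4 (the limit leaves the size open) is accordingly estimated as none beyond the scatter.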

Compound 4, half-maximal inhibitory concentration: > 1000000 nM
Compound 4: only a limit was reported; the forecaster's own chance of this, stated with the estimate: 85%; the middle value does not contradict the limit.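

In this assay compound 4 gives only a limit, > 1000000 nM. Compound 1 also stands at a limit, so the step between these two compounds cannot be read for size or direction. The compounds shown leave open whether the tert-butyl, the 2-carboxyethyl chain or the configuration changes the result at all, as none of the four has a measured number in this assay.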